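A few compounds are considered here, and "the series" means these few. Any claim that something is new, unique, unknown or untested is made for them only; others in the source may bear on it.

The series shares one core. Compound 1 `Cn1nc(COc2cccc(F)c2)c2c1CCN(C(=O)Nc1ccc(Cl)cc1)C2` carries a 3-fluorophenyl on an oxygen on a saturated carbon, compound 2 `Cn1nc(COc2cc(F)c(F)c(F)c2)c2c1CCN(C(=O)Nc1ccc(Cl)cc1)C2` a 3,4,5-trifluorophenyl there, and compound 3 `Cn1nc(COc2cc(F)cc(F)c2)c2c1CCN(C(=O)Nc1ccc(Br)cc1)C2` a 3,5-difluorophenyl there together with a bromine where the other two have a chlorine. In an assay on cells for inhibition of Pendrin (Mus musculus), read by fluorescence, with a stated time of 10 min (a higher number here means a weaker inhibitor, a lower number a stronger inhibitor), compound 1 gives 6600 nM, compound 2 gives 3300 nM and compound 3 gives 3300 nM. Among the compounds with values here, the one single-point step, a 2.0-fold lower number from compound 1 to compound 2 (0.30 log units; within the scatter), stays within the scatter. Compound 3 stands level with compound 2 at the digits shown, the two together holding the lowest numbers of the three, and within the scatter of compound 1.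

Compound 4 `CCN(CC)S(=O)(=O)N1CCc2c(c(COc3cc(F)cc(F)c3)nn2C)C1` differs from compound 3 in diethylsulfamoyl in place of (4-bromophenyl)carbamoyl on an amine nitrogen in a ring. Within the data shown here, no measured step touches this place: the only recorded step concerns the aryl ether, and compound 2 and compound 3 differ in two places at once. The expectation therefore rests on compound 3 alone and carries a wide range. For compound 4 the expected step is a 3.0-fold higher number from compound 3 to compound 4 (0.48 log units; beyond the scatter), towards a higher number. Compound 4 is estimated at 10000 nM, between 2000 nM and 50000 nM.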

Compound 4, half-maximal inhibitory concentration: > 10000 nM
Compound 4 was reported as a limit; the forecaster's own chance of this, stated with the estimate: 25%; the middle value lies on the limit itself.
By their numbers in this assay, from the lowest: compounds 2, 3 and 1 (each within the scatter of the next). At a limit, above all of these: compound 4.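

In this assay, within the data shown here, the change on the amine nitrogen in a ring gives an at least 3.0-fold higher number from compound 3 to compound 4 (0.48 log units; beyond the scatter), the only step that lies beyond the scatter. The value of compound 4, > 10000 nM, is a limit of the assay and not a number. The full size of the step stays unread because the reading for compound 4 ends at that limit: the limit of > 10000 nM in this assay, at which 1 of the 4 values shown sits.

The step exchanges the whole group, so the loss of the six-membered aromatic ring of carbon only and the loss of the hydrogen-bond donor cannot be told apart. Open too, on these data alone, is how a diethylcarbamoyl or a phenylsulfamoyl on this nitrogen would read, either of which would separate the aromatic ring from the sulfonyl link.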